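Notes on the substituent change from compound 1 to compound 4

The compounds below may be only part of what the source reports. "The series", "measured", "known", "first", "only" and "open" are said of these compounds alone.

Measured in an assay on CHO cells for displacement of a labelled ligand from 5-hydroxytryptamine receptor 1B (Homo sapiens); on this read-out lower numbers stand for stronger inhibition and higher numbers for weaker inhibition:
- compound 1 `O=S(=O)(NCC1CCN(CCCc2c[nH]c3ccc(-n4cnnc4)cc23)CC1)c1ccccc1`: 60 nM
- compound 2 `O[C@H]1Cc2ccccc2C1NC1CCN(CCCc2c[nH]c3ccc(-n4cnnc4)cc23)CC1`: 300 nM
- compound 3 `c1ccc(C2CCCCN2C2CCN(CCCc3c[nH]c4ccc(-n5cnnc5)cc34)CC2)cc1`: 410 nM

Compound 1 gives the lowest number of the three; the nearest is compound 2 and the furthest compound 3, and both gaps lie beyond the scatter. Within the data shown here, the one step with a single change is a 5.0-fold higher number from compound 1 to compound 2 (0.70 log units; beyond the scatter).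

Compound 4 `CN(Cc1cccs1)C1CCN(CCCc2c[nH]c3ccc(-n4cnnc4)cc23)CC1` is not yet measured. Relative to compound 1 the change is methyl((thiophen-2-yl)methyl)amino in place of ((phenylsulfonyl)amino)methyl on a saturated ring carbon. Among the measured compounds shown here, no measured pair covers this exact swap. Compounds 2 and 3 share with compound 4 a nitrogen joined directly to the saturated ring carbon, and their numbers in this assay are both above that of compound 1; the step of a 5.0-fold higher number from compound 1 to compound 2 (0.70 log units; beyond the scatter) is the nearest guide. A shift of similar size and direction is therefore expected, with wide uncertainty because the entering group differs from both. The expected step is a 4.2-fold higher number from compound 1 to compound 4 (0.62 log units; beyond the scatter). For compound 4 the estimate in this assay is 250 nM, within 80 nM to 800 nM.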

Compound 4, half-maximal inhibitory concentration: 140 nM
Compound 4: the middle estimate sits 1.8-fold (0.25 log units) above what was measured; the range from low to high includes it.
By their numbers in this assay, from the lowest: compound 1; then compound 4; then compounds 2 and 3 (each within the scatter of the next).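

In this assay, the saturated ring carbon still accepts a group without the phenylsulfonyl unit at modest cost: methyl((thiophen-2-yl)methyl)amino gives a 2.3-fold higher number from compound 1 to compound 4 (0.37 log units; beyond the scatter), and compound 1 keeps the lowest number. A nitrogen joined directly to this carbon does not by itself fix the number, since changing the group attached through that nitrogen gives a 2.1-fold lower number from compound 2 to compound 4 (0.33 log units; beyond the scatter). Nothing at hand explains either step.

The compounds shown leave open whether the thiophene ring or the methyl on the nitrogen accounts for the difference between compound 2 and compound 4. A benzyl(methyl)amino group or a plain ((thiophen-2-yl)methyl)amino group on this carbon would separate those two parts, and an added methylene before the nitrogen would test the link length against compound 1.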